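The source may hold more compounds than are shown below. What is called first, only, known or untested is meant among the compounds shown, and "the series" means these compounds.

Measured so far:
compound 1 `CCc1cccc2c(OC)c(-c3occ(C)c3C(=O)OC)ccc12` – 1.3 ug/mL
compound 2 `CCCOC(=O)c1c(C)coc1-c1ccc2c(CC)cccc2c1OC` – a limit, > 10 ug/mL
compound 3 `CCc1cccc2c(OC)c(-c3occ(C)c3C(=O)On3nnc4ccccc43)ccc12` – a limit, > 10 ug/mL

For the measured compounds named here, in a functional assay on ZR-75-1 cells (Homo sapiens) for cytotoxicity, read by MTT assay, with a stated time of 72 h (a lower number here means that less compound is needed, a higher number that more compound is needed for the effect), compound 1 gives 1.3 ug/mL, the only number among the three. Compound 2 sits at a limit of this assay, > 10 ug/mL. Compound 3 also sits at a limit, > 10 ug/mL (the limit of > 10 ug/mL in this assay, at which 2 of the 3 values shown sit). The two readable steps, an at least 7.6-fold higher number from compound 1 to compound 2 (0.88 log units; beyond the scatter) and an at least 7.6-fold higher number from compound 1 to compound 3 (0.88 log units; beyond the scatter), both change the group on the oxygen next to the carbonyl group.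

Compound 4 `CCOc1c(-c2occ(C)c2C(=O)OC)ccc2c(CC)cccc12` differs from compound 1 elsewhere: methyl in place of hydrogen on a saturated chain carbon bound to an oxygen on an aromatic ring. Going by the values given here, no measured step touches that place, so neither step bears directly on it. The expectation is therefore a change within the scatter or a small loss, a 1.5-fold higher number from compound 1 to compound 4 (0.19 log units; within the scatter). Compound 4 is estimated at 2 ug/mL, ranging from 0.8 ug/mL to 6 ug/mL.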

Compound 4, concentration for half-maximal effect: 1.2 ug/mL
Estimate against measurement, compound 4: 1.7-fold (0.22 log units) above, within the range that was stated.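

Methoxy to ethoxy, with methyl in place of hydrogen on a saturated chain carbon bound to an oxygen on an aromatic ring, gives a 1.1-fold lower number from compound 1 to compound 4 (0.03 log units; within the scatter) in this assay. This is the first change shown at this place, and unlike the steps at the oxygen next to a carbonyl group, it leaves the number within the scatter. No measurement shown gives a cause for this result.

From the compounds shown here alone, whether a longer chain or a chain ending in an amine or a carboxylic acid holds the number at this place remains open. So does whether ethoxy stays without effect when the group on the oxygen next to the carbonyl group also changes.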